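The source may report more compounds than this note shows. Statements on the series, on what has been measured and on what is new or still open speak of the compounds shown alone.

Measured in a functional assay on HeLa cells (Homo sapiens) for antiproliferative activity, read by sulforhodamine B assay; on this read-out lower numbers stand for stronger inhibition and higher numbers for weaker inhibition:
Compound 1 `C/C(=N\Nc1nc2ccccc2o1)c1ccccn1`: 23 nM
Compound 2 `CC(C)/C(=N\Nc1nc2ccccc2o1)c1ccccn1`: 185 nM
Compound 3 `CC(C)(C)/C(=N\Nc1nc2ccccc2o1)c1ccccn1`: > 10000 nM (a limit of the assay, not a number)

Compound 1 holds the lowest number of the three, and both steps away from it lie beyond the scatter. Compound 4 `C/C(=N\Nc1nc2ccccc2o1)c1cccnc1` carries pyridin-3-yl in place of pyridin-2-yl on a carbon with a double bond to nitrogen, (pyridin-3-yl in place of pyridin-2-yl on a carbon with a double bond to nitrogen). Within the data shown here, no measured step changes this ring, so the evidence is indirect. The nearest steps replace the methyl on that same carbon: an 8.0-fold higher number from compound 1 to compound 2 (0.91 log units; beyond the scatter), and an at least 430-fold higher number from compound 1 to compound 3 (2.63 log units; beyond the scatter). Both of these moves away from compound 1 raised the number. A step toward a higher number in this assay is therefore expected, probably larger than the modest one to compound 2, though this remains uncertain. For compound 4 the estimated value is 1500 nM, with an expected range of 150 nM to 10000 nM. This estimate amounts to an expected 65-fold higher number from compound 1 to compound 4 (1.81 log units; beyond the scatter).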

Compound 4, half-maximal inhibitory concentration: > 100000 nM
Compound 4: no number, only a limit; the forecaster's own chance of this, stated with the estimate: 25%; at least 66-fold (1.82 log units) between middle value and limit.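

In this assay, an at least 4300-fold higher number from compound 1 to compound 4 (3.63 log units; beyond the scatter). Compound 4 gives no number, only a limit of the assay: the limit of > 100000 nM in this assay, at which 1 of the 4 values shown sits. The earlier compounds shown here changed only the alkyl group on the carbon with a double bond to nitrogen, whereas this step keeps the methyl and the same atoms and shows that exchanging pyridin-2-yl for pyridin-3-yl on that carbon is enough on its own to take the read-out from a low number to a limit.

The compounds shown do not tell how pyridin-4-yl or a plain phenyl ring on that carbon would compare with compound 1 at 23 nM. They also leave open whether any other ring there, such as a thiazole or a methyl-substituted pyridin-2-yl, would keep a measurable number.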